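The source may hold more compounds than are shown below. What is called first, only, known or untested is meant among the compounds shown, and "the series" means these compounds.

Working notes on the series. Compound 1 `CC(C)C(=O)Oc1ccc2oc(/C=C/[S+](C)[O-])cc(=O)c2c1` and compound 2 `CCCCOc1ccc2oc(/C=C/[S+](C)[O-])cc(=O)c2c1` share one core and differ only at an oxygen on an aromatic ring. In a functional assay on DLD-1 cells (Homo sapiens) for cytotoxicity, with a stated time of 48 h (a higher number here means a weaker inhibitor, a lower number a stronger inhibitor), compound 1 gives 9100 nM, and in this assay compound 2 gives 4800 nM; the two numbers lie within the scatter of each other, so nothing separates them with confidence. For the measured compounds named here, the single step measured so far, a 1.9-fold lower number from compound 1 to compound 2 (0.28 log units; within the scatter), is therefore small.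

Compound 3 `CC(=O)Oc1ccc2oc(/C=C/[S+](C)[O-])cc(=O)c2c1` is the next member. Compared with compound 2 it carries acetyl in place of butyl on an oxygen on an aromatic ring. The change returns the oxygen to an acyl substituent, as in compound 1, but with a shorter chain. Going by the values given here, the only step that bears on it is the one from compound 1 to compound 2, which stayed within the scatter, so a move back toward an acyl group is not expected to shift this assay beyond the scatter either, in either direction.

The expected value for compound 3 in this assay is 7000 nM, with a range from 3000 nM to 16000 nM, which corresponds to an expected step of a 1.5-fold higher number from compound 2 to compound 3 (0.16 log units; within the scatter).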

Compound 3, half-maximal inhibitory concentration: > 10000 nM
Compound 3: only a limit was reported; the forecaster's own chance of this, stated with the estimate: 5%; middle value at least 1.4-fold (0.15 log units) from the limit.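

In this assay compound 3 is reported only as a limit of the assay, not as a number: the limit of > 10000 nM in this assay, at which 1 of the 3 values shown sits. Even so, the butoxy to acetoxy change on this oxygen gives the first step in the series that clears the scatter, an at least 2.0-fold higher number from compound 2 to compound 3 (0.31 log units; beyond the scatter), so the substituent at this position can move the read-out, and the butoxy form lies on the stronger side of that step. This is no general split between alkyl and acyl groups, since compound 1 also carries an acyl group and stays within the scatter of compound 2, while the step between the two acyl compounds, an at least 1.0-fold higher number from compound 1 to compound 3 (0.04 log units; that floor lies within the scatter), has a floor that does not separate them, so no effect of acyl chain length can be read.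

As far as these compounds go, how far compound 3 really lies beyond compound 1 stays open, as the limit gives only a floor. Also open, from the compounds shown here alone, is whether a free hydroxyl, an amine-bearing chain or a longer alkyl chain such as hexyl on this oxygen would take the number clearly under that of compound 2.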